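The source may report more compounds than this note shows. Statements on the series, on what has been measured and on what is new or still open speak of the compounds shown alone.

Measured compounds:
- compound 1, `COc1ccc(-c2cc3ccc(OCCCCCn4cc(CNC(=O)CCCCC5CCSS5)nn4)cc3oc2=O)cc1`: 45.5%
- compound 2, `O=C(CCCCC1CCSS1)NCc1cn(CCCCCOc2ccc3cc(-c4ccc(Br)cc4)c(=O)oc3c2)nn1`: 48.4%

In a functional assay on PC-12 cells (Rattus norvegicus) for cytotoxicity, read by MTT assay, with stated times of 3 h and 2 h, tested at 10 uM (on this read-out higher numbers stand for a stronger effect at the one concentration tested and lower numbers for a weaker effect), compound 1 gives 45.5% and compound 2 gives 48.4%. Going by the values given here, the one measured step, a number 2.9 percentage points higher from compound 1 to compound 2 (within the scatter), is within the scatter, so the two numbers cannot be told apart; compound 2 stands together with compound 1 in a narrow band near the middle of the percentage scale.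

Compound 3, `O=C(CCCCC1CCSS1)NCc1cn(CCCCCOc2ccc3cc(-c4ccc(Cl)c(Cl)c4)c(=O)oc3c2)nn1`, is reached from compound 2 by a single change: 3,4-dichlorophenyl in place of 4-bromophenyl on an aromatic carbon. The change is at the same place as the step from compound 1 to compound 2, which exchanged one small substituent on that aromatic carbon for another; that exchange moved the read-out by a number 2.9 percentage points higher from compound 1 to compound 2 (within the scatter). Nothing measured here concerns a second chlorine or a dichlorophenyl group. Among the compounds with values here, since the only step at this place was within the scatter, the expectation is that the read-out of compound 3 in this assay stays close to that of compound 2, with an estimated step of a number 0.6 percentage points higher from compound 2 to compound 3 (within the scatter), in no direction beyond the scatter. Compound 3 is therefore estimated at 49%, in the range 38% to 60%.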

Compound 3, a percentage reported as activity, at one concentration (the size of the read-out at that concentration, not a potency): 59.4%
The estimate for compound 3 lay 10.4 percentage points below the measured number; low and high end bracket the measured number.
By their numbers in this assay, from the lowest: compounds 1 and 2 (each within the scatter of the next); then compound 3.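

In this assay, the aryl group on this aromatic carbon, two atoms from the ring oxygen, is now shown to be able to move the read-out: the step is a number 11 percentage points higher from compound 2 to compound 3 (beyond the scatter), and against the methoxy compound it is a number 13.9 percentage points higher from compound 1 to compound 3 (beyond the scatter), whereas the 4-methoxyphenyl and 4-bromophenyl groups had stayed within the scatter of each other. Going by these compounds alone, the position is therefore not indifferent to what the phenyl ring carries, and 3,4-dichlorophenyl is the only group of the three that separates from the others, with the hydrogen-bond donor and acceptor counts of the entering and leaving groups unchanged. No measurement at hand accounts for this step.

The change from compound 2 to compound 3 replaces bromine with chlorine and also adds a second halogen, so a phenyl ring carrying one chlorine would be needed to tell which part goes with the higher number. Going by these compounds, whether the step extends to groups of another kind on this ring, such as an amine or a carboxylic acid, remains open, as does whether it holds at other concentrations, since all three numbers come from a single one.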